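From chloro to dimethylamino: what three numbers suggest

The source may report more compounds than this note shows. Statements on the series, on what has been measured and on what is new or still open speak of the compounds shown alone.

- Compound 1 `COC(=O)c1cc(CCc2ccccc2OC)ccc1O` gives 20000 nM
- Compound 2 `COC(=O)c1cc(CCc2cc(O)ccc2OC)ccc1O` gives 8700 nM
- Compound 3 `COC(=O)c1cc(CCc2cc(Cl)ccc2OC)ccc1O` gives 6900 nM

In a functional assay on HaCaT cells (Homo sapiens) for antiproliferative activity, read by sulforhodamine B assay, with a stated time of 3 days (on this read-out higher numbers stand for weaker inhibition and lower numbers for stronger inhibition), compound 3 sits at the low end of these numbers, together with compound 2, since the two cannot be told apart within the scatter. Both lie under compound 1.

The next compound, compound 4 `COC(=O)c1cc(CCc2cc(N(C)C)ccc2OC)ccc1O`, keeps the shared core but has dimethylamino in place of chloro on an aromatic carbon, para to a methoxy group (dimethylamino in place of chloro on an aromatic carbon).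

Among the compounds with values here, three measured steps concern that same carbon. Hydroxy in place of hydrogen gave a 2.3-fold lower number from compound 1 to compound 2 (0.36 log units; beyond the scatter) and chloro in place of hydrogen gave a 2.9-fold lower number from compound 1 to compound 3 (0.46 log units; beyond the scatter), both modest. The closest comparison is one group replacing another, and chloro in place of hydroxy gave a 1.3-fold lower number from compound 2 to compound 3 (0.10 log units; within the scatter) with no change beyond the scatter.

Within the data shown here, no measured compound carries dimethylamino, so this is an extrapolation. Going by a 1.3-fold lower number from compound 2 to compound 3 (0.10 log units; within the scatter) as the nearest precedent, no step beyond the scatter is expected in this assay in either direction. The estimated step is a 1.1-fold lower number from compound 3 to compound 4 (0.03 log units; within the scatter) as a best guess. Compound 4 is expected at 6500 nM, with an estimated range from 2500 nM to 17000 nM in this read-out.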

Compound 4, half-maximal inhibitory concentration: 920 nM
Compound 4: the middle estimate sits 7.1-fold (0.85 log units) above what was measured; measured number below the stated range.
By their numbers in this assay, from the lowest: compound 4; then compounds 3 and 2 (each within the scatter of the next); then compound 1.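

In this assay, within the data shown here, the earlier compounds made this carbon, para to a methoxy group, look rather insensitive to what it carries, since hydroxy and chloro could not be told apart, yet dimethylamino gives a 7.5-fold lower number from compound 3 to compound 4 (0.88 log units; beyond the scatter) and a 9.5-fold lower number from compound 2 to compound 4 (0.98 log units; beyond the scatter). Set against plain hydrogen, the same group gives a 22-fold lower number from compound 1 to compound 4 (1.34 log units; beyond the scatter), the only large step in this set, which places compound 4 alone at the low end of the numbers and shows that the choice of group at this one carbon can matter far more than the first three values suggested. Nothing available here explains why dimethylamino stands apart from chloro and hydroxy.

From the compounds shown here alone, what remains open is whether the stronger inhibition goes with the nitrogen alone or also needs its two methyl groups, a question that a plain amine or a methylamino group on this carbon would help to settle. Going by these compounds, it is also open whether a bulkier amine, such as diethylamino or morpholine, would lower the number further or raise it again.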